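Compound 3 to compound 4: a large step expected

The source may report more compounds than this note shows. Statements on the series, on what has been measured and on what is new or still open speak of the compounds shown alone.

Three compounds have been measured so far in a physicochemical assay for solubility, read by LC-MS, in phosphate buffer, with a stated time of 24 h, at pH 7.4 (on this read-out higher numbers stand for higher solubility and lower numbers for lower solubility), and they read as follows

- compound 1 `O=C1c2ccccc2CN1c1cnc(NCc2c(F)ccc3c2CCO3)n2cnnc12` gives 4000 nM
- compound 2 `C[C@@H]1CC(=O)N(c2cnc(NCc3c(F)ccc4c3CCO4)n3cnnc23)C1` gives 130000 nM
- compound 3 `O=C(Nc1cnc(NCc2c(F)ccc3c2CCO3)n2cnnc12)c1ccccc1` gives 2000 nM

Compound 3, which carries a benzamido group, sits at the low end of these numbers. One step to it shows no real difference (a 2.0-fold lower number from compound 1 to compound 3 (0.30 log units; within the scatter)), while the other is large (a 65-fold lower number from compound 2 to compound 3 (1.81 log units; beyond the scatter)).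

For the measured compounds named here, compound 4 `O=C1CC2(CC2)CN1c1cnc(NCc2c(F)ccc3c2CCO3)n2cnnc12` keeps the rest of the molecule and changes only that group (a group of 8 heavy atoms (6 carbon, 1 nitrogen, 1 oxygen; one three-membered non-aromatic ring of carbon only, one five-membered non-aromatic ring with 1 hetero atom) in place of a group of 9 heavy atoms (7 carbon, 1 nitrogen, 1 oxygen; one six-membered aromatic ring of carbon only), on an aromatic carbon). The closest guide is compound 2, whose 4-methyl-2-oxopyrrolidin-1-yl group also holds a five-membered non-aromatic ring with 1 hetero atom. That ring alone does not ensure a high number, though. Compound 1 has one too, alongside a six-membered aromatic ring of carbon only, and it stays low (a 33-fold higher number from compound 1 to compound 2 (1.51 log units; beyond the scatter)). Going by the values given here, compound 4 has no such aromatic ring, so it resembles compound 2 more, although its three-membered ring has no measured precedent here.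

Among the compounds with values here, a large upward step is therefore expected, probably somewhat smaller than the one separating compound 2 from the benzamido compound. The estimated step is a 25-fold higher number from compound 3 to compound 4 (1.40 log units; beyond the scatter) and it would lie beyond the scatter. Compound 4 is expected at 50000 nM in this assay (estimated range 12000 nM to 150000 nM).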

Compound 4, solubility: 130000 nM
Compound 4: the middle estimate sits 2.6-fold (0.41 log units) below what was measured; measured number inside the range.
By their numbers in this assay, from the lowest: compounds 3 and 1 (each within the scatter of the next); then compounds 2 and 4 (each within the scatter of the next).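

In this assay the group of compound 4, with its three-membered ring of carbon only on a five-membered non-aromatic ring with 1 hetero atom, does not change the reading from that of the methyl-bearing ring of compound 2 beyond the scatter (no change at the digits printed from compound 2 to compound 4 (within the scatter)), so this position accepts more than one such group without a real change in the number. Two large steps point the same way (a 65-fold higher number from compound 3 to compound 4 (1.81 log units; beyond the scatter) and a 33-fold higher number from compound 1 to compound 4 (1.51 log units; beyond the scatter)), and among these four compounds, with none going against it, the two groups holding a six-membered aromatic ring of carbon only give the low numbers and the two without one give the high numbers. Nothing shown gives a measured reason for this link between group and number.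

From the compounds shown here alone, what remains open is how an open-chain group such as acetamido, or a group carrying an amine or a carboxylic acid, would read on this aromatic carbon. Going by these compounds, it is also open whether the link holds for a six-membered aromatic ring containing nitrogen, such as a pyridine, or on a different core.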